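Trimethoxyphenyl Change on a Second Coumarin Linker

The source may hold more compounds than are shown below. What is called first, only, known or untested is meant among the compounds shown, and "the series" means these compounds.

Compound 1 `COc1cc(/C=C/C(=O)/C=C/c2ccccc2)ccc1OCc1cn(CCCCOc2cc(=O)oc3ccccc23)nn1` and compound 2 `COc1cc(/C=C/C(=O)/C=C/c2cc(OC)c(OC)c(OC)c2)ccc1OCc1cn(CCCCOc2cc(=O)oc3ccccc23)nn1` share one core and differ in a single place. In a functional assay on THP-1 cells (Homo sapiens) for inhibition, read by sulforhodamine B assay, with a stated time of 48 h, tested at 50 uM (a higher number here means more inhibition of growth at the concentration tested, a lower number less inhibition of growth), compound 1 gives 36%, while compound 2 gives 65%. The change between them is 3,4,5-trimethoxyphenyl in place of phenyl on a double-bonded chain carbon bound to a double-bonded chain carbon, and the step it produced is a number 29 percentage points higher from compound 1 to compound 2 (beyond the scatter).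

Compound 3 `COc1cc(/C=C/C(=O)/C=C/c2ccccc2)ccc1OCc1cn(CCCOc2cc(=O)oc3ccccc23)nn1` is built on a different core; how its core differs from that of compound 1 is not broken down here. In this assay, among the compounds with values here, compound 3 gives 48%, which places it second among the three numbers measured so far, above compound 1 and below compound 2.

Compound 4 `COc1cc(/C=C/C(=O)/C=C/c2cc(OC)c(OC)c(OC)c2)ccc1OCc1cn(CCCOc2cc(=O)oc3ccccc23)nn1` has not yet been measured. It stands to compound 3 exactly as compound 2 stands to compound 1: the change is 3,4,5-trimethoxyphenyl in place of phenyl on a double-bonded chain carbon bound to a double-bonded chain carbon, the same change at the same place. Within the data shown here, the step from compound 3 to compound 4 is expected to be of roughly the size seen before, a number 24 percentage points higher from compound 3 to compound 4 (beyond the scatter), because the one earlier pair that shows this change gave a number 29 percentage points higher from compound 1 to compound 2 (beyond the scatter). Among the measured compounds shown here, with only a single earlier example, and that one on a different core, the size remains uncertain, and it is left open whether the change acts alike on both cores. Compound 4 is therefore estimated at 72% in this assay, with a likely range from 58% to 85%.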

Compound 4, percent growth inhibition at one concentration: 79%
Estimate against measurement, compound 4: 7 percentage points below; measured number inside the range.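

Replacing phenyl with 3,4,5-trimethoxyphenyl on a double-bonded chain carbon bound to a double-bonded chain carbon again strengthens the result in this assay, and the step on the second core is a number 31 percentage points higher from compound 3 to compound 4 (beyond the scatter). Set beside the earlier pair, the two steps match in size: the same change on two cores in this assay, a number 29 percentage points higher (beyond the scatter) from compound 1 to compound 2 and a number 31 percentage points higher (beyond the scatter) from compound 3 to compound 4, 2 percentage points apart, within the scatter of two such steps. In this small series, the gain seen on the core of compound 1 therefore carried over to the core of compound 3, but two pairs tested at one concentration in one cell type do not show that it would carry over to any other core, and they do not explain why the change raises growth inhibition.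

At this place, the compounds shown carry only phenyl and 3,4,5-trimethoxyphenyl, so it remains open whether a single methoxy group, an amine or a carboxylic acid would give a step of similar size. On these data alone, it also remains open whether the same change would give a step of this size with a longer linking chain than those in compound 1 and compound 3, or whether the step would hold in other cell types.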